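This account rests on a few compounds, and the source may have more. Where it says the series, first, only, none or still open, it means among the compounds named here.

Measured so far in a functional assay on HOS-TE85 cells (Homo sapiens) for inhibition, read by CCK-8 assay, with a stated time of 72 h; on this read-out higher numbers stand for weaker inhibition and lower numbers for stronger inhibition:
Compound 2 `O=C(NCCCCc1ccccc1)c1cccc(C2SCC(=O)N2c2ccccc2)c1` gives 15.9 nM.
Compound 1 `COc1ccccc1N1C(=O)CSC1C(=O)NCCCCc1ccccc1` gives > 1000 nM, which is a limit of this assay rather than a number.

Among the measured compounds shown here, compound 2 stands as the only real number in the set; the other value is a limit. For the measured compounds named here, compound 1 and compound 2 differ in more than one place, so the pair shows only its two values and no single-point step can be drawn between measured compounds. Going by the values given here, there is thus no measured step to calibrate the next change against.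

Compound 3 `COc1ccc(N2C(=O)CSC2c2cccc(C(=O)NCCCCc3ccccc3)c2)c(OC)c1` differs from compound 2 in one place: 2,4-dimethoxyphenyl in place of phenyl on an amide-type nitrogen in a ring. Among the compounds with values here, with no measured step to lean on, the expected step in this assay is small, of a size not clearly beyond the usual scatter, and its direction is uncertain. Compound 3 is estimated at 40 nM, with a range of 10 nM to 250 nM. The step this estimate implies is a 2.5-fold higher number from compound 2 to compound 3 (0.40 log units; beyond the scatter).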

Compound 3, half-maximal inhibitory concentration: 90.4 nM
The estimate for compound 3 lay 2.3-fold (0.35 log units) below the measured number, within the range that was stated.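

In this assay, 2,4-dimethoxyphenyl in place of phenyl on the amide-type nitrogen in the ring gives a 5.7-fold higher number from compound 2 to compound 3 (0.75 log units; beyond the scatter). Among the compounds shown here, this is the first single-place step measured: the position is sensitive to this change, and the larger group gives weaker inhibition, although compound 3 still gives a real number, 90.4 nM. No data shown here bear on the reason for this step.

On these data alone, it remains open whether a single methoxy, a fluoro or an amine on that phenyl would shift the number in the same direction, or whether the two methoxy groups act together. For the compounds shown here, also open is whether the step would keep its size with a shorter chain on the amide in place of the one shared by compound 2 and compound 3.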